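The source may hold more compounds than are shown below. What is called first, only, known or untested is meant among the compounds shown, and "the series" means these compounds.

Compound 1 `CC(O)(COc1cccc(S(F)(F)(F)(F)F)c1)C(=O)Nc1ccc([N+](=O)[O-])cc1C(F)(F)F`: 12100 nM
Compound 2 `CC(O)(COc1ccc(C#N)cc1C(F)(F)F)C(=O)Nc1ccc(S(F)(F)(F)(F)F)cc1`: 100000 nM
Compound 3 `CC(O)(CS(=O)(=O)c1cccc(S(F)(F)(F)(F)F)c1)C(=O)Nc1cccc(S(F)(F)(F)(F)F)c1`: 11700 nM

All three numbers come from a functional assay on LNCaP cells (Homo sapiens) for antiproliferative activity, read by propidium iodide staining, with a stated time of 96 h; a lower number here means a stronger inhibitor, a higher number a weaker inhibitor. Compound 3, at 11700 nM, cannot be told apart from compound 1, at 12100 nM. The two values lie within the scatter of repeated measurements. Compound 2, at 100000 nM, has a higher number than compound 3, and that gap lies beyond the scatter.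

The next compound to be tested is compound 4 `CC(O)(CS(=O)(=O)c1cccc(OC(F)(F)F)c1)C(=O)Nc1cccc(S(F)(F)(F)(F)F)c1`. It differs from compound 3 in one place: a group of 5 heavy atoms (1 carbon, 1 oxygen, 3 fluorine; no ring) in place of a group of 6 heavy atoms (5 fluorine, 1 sulfur; no ring), on an aromatic carbon. The change sits on an aromatic carbon of a six-membered aromatic ring of carbon only, meta to a large group, and the rest of the structure stays the same.

Among the measured compounds shown here, no two measured compounds differ in just one place, so the data give no direct guide to the size of this step in this assay. With so local a change, no step beyond the scatter is the main expectation, and no direction is favoured strongly. Compound 2, at 100000 nM, shows that much higher numbers do occur in this small set, so the range is kept wide and reaches further upward. The expected change is small, a 1.2-fold higher number from compound 3 to compound 4 (0.08 log units; within the scatter). For compound 4 the estimated value is 14000 nM, with an expected range from 5000 nM to 40000 nM.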

Compound 4, half-maximal inhibitory concentration: 15100 nM
Beside the measured number, compound 4's estimate is 1.1-fold (0.03 log units) below it; the range from low to high includes it.
By their numbers in this assay, from the lowest: compounds 3, 1 and 4 (each within the scatter of the next); then compound 2.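

In this assay, among the compounds shown here, putting trifluoromethoxy in place of the group of 5 fluorine and 1 sulfur gives a 1.3-fold higher number from compound 3 to compound 4 (0.11 log units; within the scatter), the first change at a single place that can be read directly in this set. The swap, on an aromatic carbon of a six-membered aromatic ring of carbon only, meta to a large group, leaves the number within the scatter, so the two groups cannot be told apart here. At this position, then, the group of 5 fluorine and 1 sulfur is not required to keep the activity at this level, and an exchange for a group with one fewer heavy atom and one hydrogen-bond acceptor, where the old group has none, produces no readable change.

As far as these compounds go, it remains open whether a much different group on the same aromatic carbon, such as an amine, a carboxylic acid or a plain hydrogen, would move the number beyond the scatter, and whether the same swap would read alike at the group of 5 fluorine and 1 sulfur that both compound 3 and compound 4 keep elsewhere in the structure. No separate measurement is at hand that would help explain this result.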